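A few compounds are considered here, and "the series" means these few. Any claim that something is new, unique, unknown or untested is made for them only; others in the source may bear on it.

Among the values shown, compound 2 `Cc1ccccc1-c1nc2cc(-c3nc4cc(C#N)ccc4[nH]3)ccc2[nH]1` is the only one that is a number: in a functional assay on RPMI 8402 cells (Homo sapiens) for cytotoxicity (on this read-out higher numbers stand for weaker inhibition and lower numbers for stronger inhibition), compound 2 gives 1200 nM. Compound 1 `N#Cc1ccc2[nH]c(-c3ccc4[nH]c(-c5ccccc5)nc4c3)nc2c1` is known only as a limit of the assay, and in this assay compound 1 gives > 25000 nM. Within the data shown here, the single measured step is an at least 20-fold lower number from compound 1 to compound 2 (1.31 log units; beyond the scatter), a methyl in place of hydrogen on an aromatic carbon; because the limit of > 25000 nM in this assay, at which 1 of the 2 values shown sits, is all that is known of compound 1, the size of that step is only a lower bound.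

Compound 3 `Cc1cccc(-c2nc3cc(-c4nc5cc(C#N)ccc5[nH]4)ccc3[nH]2)c1` carries the change (3-methylphenyl in place of 2-methylphenyl on an aromatic carbon). Among the measured compounds shown here, the measured step bears on this only indirectly: it shows that a methyl in place of hydrogen moves the number a long way, yet no measured pair compares a 2-methylphenyl with a 3-methylphenyl. Since the same atoms are kept and only joined differently, the step in this assay is expected to be far smaller than the measured one, with no clear direction. Compound 3 is therefore estimated at 1500 nM, with a range from 400 nM to 6000 nM. The step this implies, a 1.3-fold higher number from compound 2 to compound 3 (0.10 log units; within the scatter), is expected to stay within the scatter.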

Compound 3, half-maximal inhibitory concentration: 860 nM
For compound 3 the middle estimate is 1.7-fold (0.24 log units) above the measured one, and the stated range covers the measured number.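

Exchanging 2-methylphenyl for 3-methylphenyl on this aromatic carbon, between two ring nitrogen atoms, gives a 1.4-fold lower number from compound 2 to compound 3 (0.14 log units; within the scatter) in this assay and so leaves the two placements of the methyl indistinguishable on this read-out. The large difference from the unsubstituted phenyl of the earlier pair therefore appears with a second placement of the methyl as well, as shown by an at least 29-fold lower number from compound 1 to compound 3 (1.46 log units; beyond the scatter) and not with the 2-methylphenyl group alone. As with the earlier step, this size is only a lower bound, since compound 1 is known only as a limit: the limit of > 25000 nM in this assay, at which 1 of the 3 values shown sits.

These three compounds show only that a methyl at either of these two placements goes with a lower number than the limit of the parent, and they give no reason for that difference. Whether the effect belongs to methyl itself remains open, as the compounds shown include no phenyl ring carrying another group, such as a methoxy group, a chlorine atom, an amine, a carboxylic acid or a longer chain like ethyl.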